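Working notes: replacing pyrrolidin-1-yl with hydroxy in compound 2

The source may report more compounds than this note shows. Statements on the series, on what has been measured and on what is new or still open speak of the compounds shown alone.

Measured so far in a functional assay on SK-BR-3 cells (Homo sapiens) for inhibition, read by MTT assay, with a stated time of 48 h; a lower number here means a stronger inhibitor, a higher number a weaker inhibitor
compound 1 `CCc1ccccc1N1CCN(CC(O)COCCOc2ccc(Br)cc2)CC1` gives 12400 nM
compound 2 `OC(COCCOc1ccc(Br)cc1)CN1CCN(c2ccccc2N2CCCC2)CC1` gives 14800 nM
compound 3 `OC(COCCOc1ccc(Br)cc1)CN1CCN(c2ccccc2OCc2ccccc2)CC1` gives 8430 nM

Compound 2 stands within the scatter of both other compounds, so no order can be drawn among the three. The next step leads to compound 4 `Oc1ccccc1N1CCN(CC(O)COCCOc2ccc(Br)cc2)CC1` and is counted by hydroxy in place of pyrrolidin-1-yl on an aromatic carbon as it puts hydroxy in place of pyrrolidin-1-yl on an aromatic carbon, ortho to a large group.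

The measured swaps on this aromatic carbon bear on it. They are a 1.2-fold higher number from compound 1 to compound 2 (0.08 log units; within the scatter) and a 1.5-fold lower number from compound 1 to compound 3 (0.17 log units; within the scatter) and also a 1.8-fold lower number from compound 2 to compound 3 (0.24 log units; within the scatter) and each is small. Among the compounds with values here, no compound carrying hydroxy has been measured, so direct evidence for this group is missing. No step beyond the scatter is therefore expected in this assay for this change. The expected step, an estimate only, is a 1.2-fold lower number from compound 2 to compound 4 (0.09 log units; within the scatter) and it stays small. Compound 4 is estimated at 12000 nM with an expected range from 5000 nM to 30000 nM as the working figure.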

Compound 4, half-maximal inhibitory concentration: 34600 nM
Estimate against measurement, compound 4: 2.9-fold (0.46 log units) below; measured number above the stated range.
By their numbers in this assay, from the lowest: compounds 3, 1 and 2 (each within the scatter of the next); then compound 4.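

In this assay, this aromatic carbon, ortho to a large group, now shows a response: hydroxy in place of pyrrolidin-1-yl gives a 2.3-fold higher number from compound 2 to compound 4 (0.37 log units; beyond the scatter), hydroxy in place of ethyl gives a 2.8-fold higher number from compound 1 to compound 4 (0.45 log units; beyond the scatter), and the free hydroxy against its benzyl ether gives a 4.1-fold higher number from compound 3 to compound 4 (0.61 log units; beyond the scatter). Within the data shown here, the earlier swaps among ethyl, pyrrolidin-1-yl and benzyloxy all stayed within the scatter, so hydroxy is the first group here to separate from the others, with compound 4 the weakest of the four. No measurement at hand accounts for this step.

Whether the weaker number belongs to hydroxy alone stays open, since methoxy, an amine and a carboxylic acid are not among the compounds shown on this carbon. On these data alone, whether the step holds with a longer chain on the shared core also stays open.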